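The source may hold more compounds than are shown below. What is called first, only, known or untested is meant among the compounds shown, and "the series" means these compounds.

Of the compounds shown here, three sharing a core have been tested in a functional assay on BT-474 cells (Homo sapiens) for inhibition, read by fluorescence, with a stated time of 72 h; on this read-out lower numbers stand for stronger inhibition of growth and higher numbers for weaker inhibition of growth. Compound 1 (`N[C@H]1CC[C@H](Nc2nc(Nc3ccc(Cl)cc3)c3ncn(C4CCCCC4)c3n2)CC1`) gives 4100 nM, compound 2 (`CC(C)=CCn1cnc2c(Nc3cccc(Cl)c3)nc(N[C@H]3CC[C@H](N)CC3)nc21`) gives 7000 nM, and compound 3 (`CCCCn1cnc2c(Nc3ccccc3)nc(N[C@H]3CC[C@H](N)CC3)nc21`) gives 4900 nM. Compound 2 therefore stands within the scatter of both of the others. The three differ from one another in more than one place, so no single structural change can be read from them.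

Compound 4 (`CC(C)=CCC/C(C)=C/Cn1cnc2c(Nc3cccc(Cl)c3)nc(N[C@H]3CC[C@H](N)CC3)nc21`) departs from compound 2 through (3-methylbut-2-en-1-yl in place of hydrogen on a saturated chain carbon bound to a double-bonded chain carbon), which turns the 3-methylbut-2-en-1-yl into 3,7-dimethylocta-2,6-dien-1-yl. Among the compounds with values here, no measurement yet shows what such a change does in this assay. Within the data shown here, the values so far lie close together, with compound 3 at 4900 nM and compound 1 at 4100 nM, so no step beyond the scatter is expected. The expected step, a 1.4-fold lower number from compound 2 to compound 4 (0.15 log units; within the scatter), is small, points towards a lower number and stays within the scatter. For compound 4 the estimated value is 5000 nM, with an expected range from 1800 nM to 14000 nM.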

Compound 4, concentration for 50% growth inhibition: 4300 nM
Compound 4: middle estimate off by 1.2-fold (0.07 log units), on the high side, within the range that was stated.
By their numbers in this assay, from the lowest: compounds 1, 4, 3 and 2 (each within the scatter of the next).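

In this assay, within the data shown here, the change from 3-methylbut-2-en-1-yl to 3,7-dimethylocta-2,6-dien-1-yl gives a 1.6-fold lower number from compound 2 to compound 4 (0.21 log units; within the scatter) and provides the first comparison between two compounds that differ in one place. At this saturated chain carbon bound to a double-bonded chain carbon, the added 3-methylbut-2-en-1-yl therefore leaves the read-out within the scatter of the shorter chain. No measurement shown gives a cause for this result.

From the compounds shown here alone, whether a chain carrying an amine or a carboxylic acid in place of 3,7-dimethylocta-2,6-dien-1-yl would move the number beyond the scatter remains open. Also open, going by these compounds, is whether the same extension would give a similar step on a compound with a different group elsewhere on the shared core.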